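Replacing the iodo group of compound 1 with a pentyl chain

The compounds below may be only part of what the source reports. "The series", "measured", "known", "first", "only" and "open" are said of these compounds alone.

Measured compounds:
compound 1, `O=C1NCCN1c1ccc(S(=O)(=O)Nc2ccc(I)cc2)cc1`: 650 nM
compound 2, `Cc1cc(C)cc(NS(=O)(=O)c2ccc(N3CCNC3=O)cc2)c1`: 82 nM
compound 3, `O=C1NCCN1c1ccc(S(=O)(=O)Nc2cccc(Cl)c2)cc1`: 55 nM

Compound 1 has the highest number of the three in a functional assay on HT-29 cells (Homo sapiens) for antiproliferative activity, read by sulforhodamine B assay, with a stated time of 48 h; a lower number here means a stronger inhibitor, a higher number a weaker inhibitor. Its nearest neighbour is compound 2, reached by a 7.9-fold lower number from compound 1 to compound 2 (0.90 log units; beyond the scatter); compound 3 lies furthest away, reached by a 12-fold lower number from compound 1 to compound 3 (1.07 log units; beyond the scatter). Between compound 2 and compound 3 the step is a 1.5-fold lower number from compound 2 to compound 3 (0.17 log units; within the scatter).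

The unmeasured compound 4, `CCCCCc1ccc(NS(=O)(=O)c2ccc(N3CCNC3=O)cc2)cc1`, differs from compound 1 in one place: pentyl in place of iodo on an aromatic carbon. Among the compounds with values here, none of the measured steps makes this exact change; both steps away from compound 1 swap the whole 4-iodophenyl for a differently substituted phenyl, and both lower the number by large amounts. Within the data shown here, they show only that compound 1 sits at the weak end of the set and that changes on the sulfonamide nitrogen can move the number far. The pentyl group keeps the substituent at the place where the iodo sat, para to a large group, so the step is expected to be smaller than those two. Compound 4 is expected to give about 350 nM in this assay, within 100 nM to 1500 nM, a step of a 1.9-fold lower number from compound 1 to compound 4 (0.27 log units; within the scatter) expected toward a lower number.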

Compound 4, half-maximal inhibitory concentration: 990 nM
Compound 4: middle estimate off by 2.8-fold (0.45 log units), on the low side; the measured number falls inside the stated range.
By their numbers in this assay, from the lowest: compounds 3 and 2 (each within the scatter of the next); then compounds 1 and 4 (each within the scatter of the next).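

In this assay, the step of a 1.5-fold higher number from compound 1 to compound 4 (0.18 log units; within the scatter) is the first shown that changes only the substituent on an aromatic carbon, para to a large group, and it lies within the scatter. At this place, the iodo group and the pentyl chain cannot be told apart, although they differ in both size and element make-up. The large steps away from compound 1 came with swaps of the whole 4-iodophenyl group, and this single exchange does not repeat them, while nothing measured here explains why the two groups read alike.

As far as these compounds go, it remains open whether an ethyl group, a longer chain such as octyl, an amine or a carboxylic acid at this place would also stay within the scatter of compound 1.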